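The source may report more compounds than this note shows. Statements on the series, on what has been measured and on what is new or still open speak of the compounds shown alone.

Compound 1: `Cc1nc(S(C)(=O)=O)ccc1Oc1ncnc(OC2CCN(C(=O)OC(C)(C)C#N)CC2)c1F` — 92.9 nM
Compound 2: `Cc1nc(S(C)(=O)=O)ccc1Oc1ncnc(OC2CCN(C(=O)O[C@@H](C)C(F)(F)F)CC2)c1F` — 9.86 nM

Among these two compounds, compound 2 gives the lowest number in a functional assay on isolated protein for inhibition of Glucose-dependent insulinotropic receptor (Homo sapiens), read by HTRF and cAMP accumulation; on this read-out lower numbers stand for an effect already at smaller amounts and higher numbers for an effect only at larger amounts of compound; the only neighbour is compound 1, whose step a 9.4-fold lower number from compound 1 to compound 2 (0.97 log units; beyond the scatter) lies beyond the scatter. Compound 3, `CCC1(OC(=O)N2CCC(Oc3ncnc(Oc4ccc(S(C)(=O)=O)nc4C)c3F)CC2)CC1`, differs from compound 2 by 1-ethylcyclopropyl in place of 1-(trifluoromethyl)ethyl on an oxygen next to a carbonyl group. Within the data shown here, only one measured step touches this carbamate position, a 9.4-fold lower number from compound 1 to compound 2 (0.97 log units; beyond the scatter), and it concerns a different exchange, so it gives little guidance. A small loss is expected for compound 3, and the step of a 2.0-fold higher number from compound 2 to compound 3 (0.31 log units; beyond the scatter) is the estimate. Compound 3 is therefore expected at 20 nM in this assay, within 5 nM to 80 nM.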

Compound 3, half-maximal effective concentration: 22 nM
Estimate against measurement, compound 3: 1.1-fold (0.04 log units) below, and the stated range covers the measured number.
By their numbers in this assay, from the lowest: compound 2; then compound 3; then compound 1.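

On the oxygen next to a carbonyl group, 1-ethylcyclopropyl, built of carbon only, still performs well in this assay: replacing 1-(trifluoromethyl)ethyl gives a 2.2-fold higher number from compound 2 to compound 3 (0.35 log units; beyond the scatter), a modest loss. Replacing 1-cyano-1-methylethyl gives a 4.2-fold lower number from compound 1 to compound 3 (0.63 log units; beyond the scatter), so among these three compounds, a low number does not depend on fluorine or a nitrile in this group. Nothing shown gives a reason for these steps. Still open, as far as these compounds go, is how a longer chain, or a ring carrying an amine, would fare on this oxygen. The mirror-image form of 1-(trifluoromethyl)ethyl also remains an open comparison.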